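The source may hold more compounds than are shown below. What is called first, only, known or untested is meant among the compounds shown, and "the series" means these compounds.

Compound 1 `COc1ccc(CNc2ncnc3c2ncn3C2CCCCO2)cc1OC` and compound 2 `COc1cc(OC)c(OC)cc1CNc1ncnc2c1ncn2C1CCCCO1` share a core; how that core differs from the core of compound 3 `COc1cccc(CNc2ncnc3c2ncn3C2CCCO2)c1` is not broken down here. Compound 4 `COc1ccc(OC)c(CNc2ncnc3c2ncn3C2CCCO2)c1` has not yet been measured. In an ADME assay on MCF7 cells (Homo sapiens) for cytotoxicity, with a stated time of 72 h (on this read-out higher numbers stand for weaker inhibition and lower numbers for stronger inhibition), compound 1 gives only a limit of the assay, > 100000 nM. In this assay compound 2 likewise gives only a limit, > 100000 nM. The change between them is methoxy in place of hydrogen on an aromatic carbon, and the step that the two limits leave unreadable from compound 1 to compound 2 cannot be read. In this assay compound 3 also gives only a limit, > 100000 nM. The change from compound 3 to compound 4 is the same kind of change, (methoxy in place of hydrogen on an aromatic carbon); here the entering group sits ortho to a large group and para to a methoxy group, whereas in compound 2 it sits ortho to a large group, meta to a methoxy group and para to a methoxy group. Every measured value sits at the limit of > 100000 nM in this assay, at which 3 of the 3 values shown sit. Because the limit of > 100000 nM in this assay, at which 3 of the 3 values shown sit, holds all three values, the step that the limit leaves unreadable from compound 3 to compound 4 is expected to be small. Compound 4 is therefore estimated at 150000 nM in this assay, most likely again reported only as a limit.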

Compound 4, half-maximal inhibitory concentration: > 50000 nM
Compound 4 was reported as a limit (the forecaster's own chance of this, stated with the estimate: 85%); the middle value is on the limit's open side.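

In this assay compound 4 gives only a limit, > 50000 nM. Compound 3 also stands at a limit, so the step from compound 3 to compound 4 cannot be read. The compounds shown leave open whether methoxy in place of hydrogen on an aromatic carbon changes inhibition in this assay at all: all four values are limits.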